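From isopentyl to cyclopentyl: a step not yet measured

The compounds below may be only part of what the source reports. "The series", "measured", "known", "first", "only" and "open" are said of these compounds alone.

Compound 1 `CC(C)CC/N=C(\NC#N)Nc1cc(C(F)(F)F)cc(C(F)(F)F)c1`: 4700 nM
Compound 2 `C[C@H](/N=C(\NC#N)Nc1cc(C(F)(F)F)cc(C(F)(F)F)c1)C(C)(C)C`: 12000 nM
Compound 3 `C[C@@H](/N=C(\NC#N)Nc1cc(C(F)(F)F)cc(C(F)(F)F)c1)C(C)(C)C`: 18000 nM

In a functional assay on Beta-TC3 cells (Rattus norvegicus) with Beta-TC3 (Mus musculus) as the target, using a membrane potential dye (a lower number here means a stronger inhibitor, a higher number a weaker inhibitor), compound 1 holds the lowest of the three numbers, and the other two compounds both lie beyond the scatter from it. Compound 4 `N#CN/C(=N\C1CCCC1)Nc1cc(C(F)(F)F)cc(C(F)(F)F)c1` has not yet been measured. It carries cyclopentyl in place of isopentyl on a double-bonded nitrogen.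

The nearest evidence comes from two other replacements of isopentyl on that nitrogen. Placing 1,2,2-trimethylpropyl there gives a 2.6-fold higher number from compound 1 to compound 2 (0.41 log units; beyond the scatter) and a 3.8-fold higher number from compound 1 to compound 3 (0.58 log units; beyond the scatter), both modest. Those two compounds are separated only by the fact that compounds 2 and 3 differ only in the configuration as drawn, and the gap is a 1.5-fold higher number from compound 2 to compound 3 (0.18 log units; within the scatter). Neither carries cyclopentyl, and no ring at this place has been measured, so the guide is a loose one.

A modest rise in the number is still expected in this assay. The expected step is a 1.5-fold higher number from compound 1 to compound 4 (0.17 log units; within the scatter). For compound 4 the estimate is 7000 nM, with an expected range from 2500 nM to 20000 nM.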

Compound 4, half-maximal inhibitory concentration: 4700 nM
Compound 4: middle estimate off by 1.5-fold (0.17 log units), on the high side; low and high end bracket the measured number.
By their numbers in this assay, from the lowest: compounds 1 and 4 (each within the scatter of the next); then compounds 2 and 3 (each within the scatter of the next).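

In this assay, cyclopentyl in place of isopentyl on a double-bonded nitrogen gives no change at the digits printed from compound 1 to compound 4 (within the scatter), so this position takes this ring of carbon as readily as the open chain. Cyclopentyl also parts from 1,2,2-trimethylpropyl, with a 2.6-fold lower number from compound 2 to compound 4 (0.41 log units; beyond the scatter) and a 3.8-fold lower number from compound 3 to compound 4 (0.58 log units; beyond the scatter), so the rise seen earlier belongs to that group and does not follow every replacement of isopentyl. Both comparisons point the same way, and they can be read as two views of one group on this ground: the fact that compounds 2 and 3 differ only in the configuration as drawn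

The compounds shown leave open whether cyclopropyl or cyclohexyl would sit with cyclopentyl or with 1,2,2-trimethylpropyl in this assay. They also leave open whether a ring holding oxygen, such as tetrahydropyranyl, or a chain ending in an amine would be tolerated on this nitrogen.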